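Hydroxyacyl side-chain variation and microsomal clearance

The source may report more compounds than this note shows. Statements on the series, on what has been measured and on what is new or still open speak of the compounds shown alone.

Three compounds on the shared core have readings in an ADME assay on liver for metabolic stability, with Liver microsome (Homo sapiens) as the target, read by LC-MS, using microsomes; on this read-out higher numbers stand for fast clearance and lower numbers for slow clearance. Compound 1 `CC(C)(C)[C@@H](O)C(=O)N1CSC[C@H]1C(=O)NCc1cc(Cl)ccc1-n1cnnn1` is the only one with a numeric result: in this assay compound 1 gives 120 mL.min-1.g-1. Compound 2 `O=C(NCc1cc(Cl)ccc1-n1cnnn1)[C@@H]1[C@H]2C[C@H]2CN1C(=O)[C@H](O)CC1CC1` returns only a limit of the assay, as in this assay compound 2 gives < 14 mL.min-1.g-1, which is the limit of < 14 mL.min-1.g-1 in this assay, at which 1 of the 3 values shown sits. Compound 3 `CCCC[C@@H](O)C(=O)N1N=CC[C@H]1C(=O)NCc1cc(Cl)ccc1-n1cnnn1` also returns only a limit, since in this assay compound 3 gives < 12 mL.min-1.g-1, which is the limit of < 12 mL.min-1.g-1 in this assay, at which 1 of the 3 values shown sits. Compound 3 therefore stands at the slow-clearance end of what the assay can report, with compound 2 at a neighbouring limit and compound 1 well apart from both. Among the compounds with values here, no single-point step between the measured compounds is available, so no measured size of effect for any change can be quoted.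

Compound 4 `O=C(NCc1cc(Cl)ccc1-n1cnnn1)[C@@H]1CC=NN1C(=O)[C@H](O)c1ccccc1F` is not yet measured. It differs from compound 3 by 2-fluorophenyl in place of butyl on a saturated chain carbon bound to a carbonyl carbon and an oxygen on a saturated carbon. With compound 3 at a limit, any result for compound 4 that also sits at a limit would be indistinguishable from it; the expected step of an at least 1.2-fold higher number from compound 3 to compound 4 (0.09 log units; that floor lies within the scatter) is small and most likely within the scatter, though a move toward faster clearance cannot be excluded. Compound 4 is therefore estimated at 15 mL.min-1.g-1, within a range from 7 mL.min-1.g-1 to 45 mL.min-1.g-1, with a fair chance that only a limit is reported.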

Compound 4, intrinsic clearance in microsomes: 16 mL.min-1.g-1
The estimate for compound 4 lay 1.1-fold (0.03 log units) below the measured number, and the stated range covers the measured number.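

Within the data shown here, the swap of butyl for 2-fluorophenyl gives the first single-place comparison: in this assay it produces an at least 1.3-fold higher number from compound 3 to compound 4 (0.12 log units; that floor lies within the scatter). Compound 4 gives 16 mL.min-1.g-1, so this carbon on the shared core now has a numeric reading to serve as a reference for further changes, and the aromatic ring of carbon only is shown to be compatible with a reading close to the low end of what the assay reports. Compound 3 remains a limit of the assay, so only a floor for the step is known and its true size cannot be read: the limit of < 12 mL.min-1.g-1 in this assay, at which 1 of the 4 values shown sits.

From the compounds shown here alone, whether the aromatic ring or the fluorine matters more for the reading at this carbon remains open, since the two enter together in a single change. Unsubstituted phenyl, a longer chain or an amine on the same carbon, with a numeric reading for the partner compound, would show whether any change at this position moves clearance beyond the usual scatter.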